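The compounds below may be only part of what the source reports. "The series", "measured", "known", "first", "only" and "open" are said of these compounds alone.

Measured compounds:

- Compound 1 `Nc1nc(Cl)c(-c2ccccn2)c(N[C@@H]2C[C@H](CO)[C@@H](O)[C@H]2O)n1`. In an ADME assay on cells (Homo sapiens) for cytotoxicity, read by polymerase chain reaction, with a stated time of 3 days (on this read-out lower numbers stand for higher toxicity in this test and higher numbers for lower toxicity in this test), compound 1 gives > 25000 nM, which is a limit of the assay and not a number.
- Compound 2 `Nc1nc(Cl)c(-c2nccs2)c(N[C@@H]2C[C@H](CO)[C@@H](O)[C@H]2O)n1`. In this assay compound 2 gives > 25000 nM, again a limit.
- Compound 3 `COc1ccc2nc(-c3c(Cl)nc(N)nc3N[C@@H]3C[C@H](CO)[C@@H](O)[C@H]3O)sc2c1`. In this assay compound 3 gives > 25000 nM, also a limit.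

Compound 3 therefore stands only at a limit, and the two other values shown are limits as well (the limit of > 25000 nM in this assay, at which 3 of the 3 values shown sit). Among the measured compounds shown here, the one step between measured compounds, a step that the two limits leave unreadable from compound 1 to compound 2, is left unreadable by the two limits, so no measured step gives a size to work from.

Compound 4 `CN(C)c1ccc2nc(-c3c(Cl)nc(N)nc3N[C@@H]3C[C@H](CO)[C@@H](O)[C@H]3O)sc2c1` differs from compound 3 by dimethylamino in place of methoxy on an aromatic carbon. For the measured compounds named here, no measured step bears on this change, and every value shown sits at the limit (the limit of > 25000 nM in this assay, at which 3 of the 3 values shown sit), so no step beyond the scatter in this assay is expected in either direction. The expected step is a step that the limit leaves unreadable from compound 3 to compound 4. For compound 4 the estimate in this assay is 30000 nM, with a range from 10000 nM to 100000 nM, and the result is expected most likely to be reported as a limit again.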

Compound 4, half-maximal cytotoxic concentration: > 25000 nM
Compound 4: only a limit was reported; the forecaster's own chance of this, stated with the estimate: 85%; the middle value is on the limit's open side.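

In this assay compound 4 gives > 25000 nM, a limit and not a number, so no step can be read from compound 3 to compound 4, and the series stays at the limit: the limit of > 25000 nM in this assay, at which 4 of the 4 values shown sit.

The compounds shown leave open what size any change of group has in this assay, and whether any change gives a readable value.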